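A few compounds are considered here, and "the series" means these few. Any claim that something is new, unique, unknown or untested is made for them only; others in the source may bear on it.

Measured in an assay on isolated protein for binding affinity to Gonadotropin-releasing hormone receptor (Rattus norvegicus); on this read-out lower numbers stand for stronger inhibition and higher numbers for weaker inhibition:

compound 1 `Cc1cc2c(cc1Cc1ccc(C(=O)NCC3CCCCC3)o1)C(C)(C)CCC2(C)C` gives 1550 nM
compound 2 `Cc1cc2c(cc1Cc1ccc(C(=O)NC[C@H]3CC[C@H](C(N)=O)CC3)o1)C(C)(C)CCC2(C)C` gives 270 nM
compound 3 `Cc1cc2c(cc1Cc1ccc(C(=O)NCc3ccccc3)o1)C(C)(C)CCC2(C)C` gives 240 nM

Compound 3 holds the lowest number of the three; compound 2 sits within the scatter of it, the step being a 1.1-fold lower number from compound 2 to compound 3 (0.05 log units; within the scatter), while compound 1 lies well apart, the step being a 6.5-fold lower number from compound 1 to compound 3 (0.81 log units; beyond the scatter). Compound 4 `Cc1cc2c(cc1Cc1ccc(C(=O)NCC3CCCC(CN)C3)o1)C(C)(C)CCC2(C)C` carries 3-(aminomethyl)cyclohexyl in place of phenyl on a saturated chain carbon bound to an amide-type nitrogen. Within the data shown here, two measured steps bear on this. Going from plain cyclohexyl to phenyl gave a 6.5-fold lower number from compound 1 to compound 3 (0.81 log units; beyond the scatter); adding a polar group to the cyclohexyl gave a 5.7-fold lower number from compound 1 to compound 2 (0.76 log units; beyond the scatter). A ring with an aminomethyl group is thus expected to land between compound 1 and compound 3, nearer to compound 2. The step of a 2.1-fold higher number from compound 3 to compound 4 (0.32 log units; beyond the scatter) is the expected change in this assay. Compound 4 is estimated at 500 nM, within 150 nM to 1600 nM.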

Compound 4, inhibition constant: 890 nM
Estimate against measurement, compound 4: 1.8-fold (0.25 log units) below, and the stated range covers the measured number.
By their numbers in this assay, from the lowest: compounds 3 and 2 (each within the scatter of the next); then compounds 4 and 1 (each within the scatter of the next).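

In this assay, a substituent on the cyclohexyl ring does not by itself shift the number: aminomethyl in place of hydrogen on a saturated ring carbon stays within the scatter (a 1.7-fold lower number from compound 1 to compound 4 (0.24 log units; within the scatter)). The 3-(aminomethyl)cyclohexyl group falls short of both 4-carbamoylcyclohexyl (a 3.3-fold higher number from compound 2 to compound 4 (0.52 log units; beyond the scatter)) and phenyl (a 3.7-fold higher number from compound 3 to compound 4 (0.57 log units; beyond the scatter)), so the gain at this position depends on which group is present. No evidence explains these differences.

As far as these compounds go, whether the gap between compound 2 and compound 4 follows the group or its place on the ring stays open. So does the effect of a carboxylic acid or a longer aminoalkyl chain on the cyclohexyl ring.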